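The source may hold more compounds than are shown below. What is called first, only, known or untested is meant among the compounds shown, and "the series" means these compounds.

Compounds measured in a functional assay, read by spectrophotometry, with a stated time of 5 min; a higher number here means a weaker inhibitor, a lower number a stronger inhibitor:
- compound 1 `COc1cc(/C=C/C(=O)C(=Cc2ccc(OC)c(OC)c2)C(=O)/C=C/c2ccc(O)c(OC)c2)ccc1O`: 6760 nM
- compound 2 `CCOc1cc(C=C(C(=O)/C=C/c2ccc(O)c(OC)c2)C(=O)/C=C/c2ccc(O)c(OC)c2)ccc1O`: 3980 nM

With only these two compounds measured in this assay, compound 2 lies within the scatter of compound 1, and neither can be ranked above the other. The next compound is compound 3 `COc1cc(/C=C/C(=O)C(=Cc2ccc(O)cc2)C(=O)/C=C/c2ccc(O)c(OC)c2)ccc1O`, which differs from compound 2 as follows: hydrogen in place of ethoxy on an aromatic carbon. This is hydrogen in place of ethoxy on an aromatic carbon, ortho to a hydroxy group, so 3-ethoxy-4-hydroxyphenyl becomes 4-hydroxyphenyl.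

Within the data shown here, only one measured step bears on this, and only indirectly. It alters the same aryl group, with 3-ethoxy-4-hydroxyphenyl in place of 3,4-dimethoxyphenyl, and amounts to a 1.7-fold lower number from compound 1 to compound 2 (0.23 log units; within the scatter). Among the measured compounds shown here, no measured pair shows the loss of ethoxy on its own, so the data give no direction for it. On that single small step, no shift beyond the scatter is expected, though the uncertainty is wide. The expected change is a 1.1-fold higher number from compound 2 to compound 3 (0.05 log units; within the scatter). Compound 3 is estimated at 4500 nM, with an expected range from 1800 nM to 11000 nM.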

Compound 3, half-maximal inhibitory concentration: 6320 nM
Estimate against measurement, compound 3: 1.4-fold (0.15 log units) below, within the range that was stated.
By their numbers in this assay, from the lowest: compounds 2, 3 and 1 (each within the scatter of the next).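

In this assay the ethoxy group, ortho to a hydroxy group, is now removed on its own, turning 3-ethoxy-4-hydroxyphenyl into 4-hydroxyphenyl, and the result is a 1.6-fold higher number from compound 2 to compound 3 (0.20 log units; within the scatter), so taking this group away leaves the number within the scatter. The second new comparison, 4-hydroxyphenyl in place of 3,4-dimethoxyphenyl, gives a 1.1-fold lower number from compound 1 to compound 3 (0.03 log units; within the scatter), and the three aryl groups now seen on this chain carbon cannot be told apart in this assay. No independent measurement is available to account for these small steps.

The compounds shown leave open whether an amine, a carboxylic acid or a longer chain such as butoxy on this aromatic carbon would move the number beyond the scatter. No pair shown removes just one of the two methoxy groups of 3,4-dimethoxyphenyl, so the contribution of each to the step between these compounds cannot be read separately.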